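Swapping a chloropropyl chain for a methoxyphenyl ring

This account rests on a few compounds, and the source may have more. Where it says the series, first, only, none or still open, it means among the compounds named here.

Compound 2 `O=C1O[C@H]([C@@H](O)Cn2cc(CCCCl)nn2)C(OCc2ccccc2)=C1OCc1ccccc1` was tested in a functional assay on HeLa cells (Homo sapiens) for antiproliferative activity, read by MTT assay, with a stated time of 72 h (on this read-out higher numbers stand for weaker inhibition and lower numbers for stronger inhibition), where compound 2 gives 36700 nM. Among the measured compounds shown here, that is the lower of the two numbers so far, but its only neighbour, compound 1 `O=C1O[C@H]([C@@H](O)Cn2cc(-c3cc(F)cc(F)c3)nn2)C(OCc2ccccc2)=C1OCc1ccccc1`, is within the scatter: in this assay compound 1 gives 40800 nM. Compound 3 `COc1ccc(-c2cn(C[C@H](O)[C@H]3OC(=O)C(OCc4ccccc4)=C3OCc3ccccc3)nn2)cc1` carries a different group at the same position: 4-methoxyphenyl in place of 3-chloropropyl on an aromatic carbon. For the measured compounds named here, the one step that bears on this place, a 1.1-fold lower number from compound 1 to compound 2 (0.05 log units; within the scatter), shows an aryl group and a chain giving much the same number. The same is therefore expected here, a 1.0-fold higher number from compound 2 to compound 3 (0.02 log units; within the scatter), with no step beyond the scatter. Compound 3 is estimated at 38000 nM, between 15000 nM and 95000 nM.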

Compound 3, half-maximal inhibitory concentration: 16400 nM
The estimate for compound 3 lay 2.3-fold (0.36 log units) above the measured number, within the range that was stated.
By their numbers in this assay, from the lowest: compound 3; then compounds 2 and 1 (each within the scatter of the next).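

Changes at this position can shift the number after all: there is a 2.2-fold lower number from compound 2 to compound 3 (0.35 log units; beyond the scatter) when 4-methoxyphenyl replaces 3-chloropropyl, and a 2.5-fold lower number from compound 1 to compound 3 (0.40 log units; beyond the scatter) when it replaces 3,5-difluorophenyl, both modest steps in this assay on this read-out. An aromatic ring here is not enough by itself, since compound 1 also carries one and stays within the scatter of compound 2. Nothing available explains why 4-methoxyphenyl stands apart.

Going by these compounds, whether an amine or a carboxylic acid at this position would lower the number further remains open. So does the outcome with a 3-methoxyphenyl group, which would test where the methoxy group sits on the ring.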